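The source may report more compounds than this note shows. Statements on the series, on what has been measured and on what is new or still open speak of the compounds shown alone.

Compound 1 `C[C@H]1CC[C@@H]2[C@@H](OC(=O)[C@]23CC(c2ccc(Cl)cc2)N(c2ccccc2)O3)[C@]2(C)C(=O)C=C[C@@]12O` and compound 2 `C[C@H]1CC[C@@H]2[C@@H](OC(=O)[C@]23CC(c2ccc(F)cc2)N(c2ccccc2)O3)[C@]2(C)C(=O)C=C[C@@]12O` share the same core and differ only in one halogen on an aromatic ring. In a physicochemical assay for lipophilicity (on this read-out lower numbers stand for lower lipophilicity and higher numbers for higher lipophilicity), compound 1 gives 3.87 and compound 2 gives 3.35, which makes compound 2 the lower of the two measured compounds. The next compound, compound 3 `Cc1ccc(C2C[C@@]3(ON2c2ccccc2)C(=O)O[C@@H]2[C@H]3CC[C@H](C)[C@]3(O)C=CC(=O)[C@@]23C)cc1`, keeps that core and changes the same aromatic carbon: methyl in place of fluoro on an aromatic carbon. This is methyl in place of fluoro on an aromatic carbon, or 4-fluorophenyl to 4-methylphenyl.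

Among the compounds with values here, only one measured step bears on this change: a number 0.52 log units lower from compound 1 to compound 2 (beyond the scatter), with fluoro in place of chloro on an aromatic carbon. That step was modest but beyond the scatter. Within the data shown here, no compound with methyl at this place has been measured, so the comparison is indirect and rests on a single pair. Fluoro leaves again here, so a modest rise in this assay is expected, similar to or slightly smaller than the size of the measured step. The expected change is a number 0.40 log units higher from compound 2 to compound 3 (beyond the scatter). For compound 3 the estimated value is 3.75, within an expected range of 3.45 to 4.05.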

Compound 3, partition coefficient: 3.64
Estimate against measurement, compound 3: 0.11 log units above; low and high end bracket the measured number.
By their numbers in this assay, from the lowest: compounds 2, 3 and 1 (each within the scatter of the next, the first and the last beyond it).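

In this assay, putting methyl in place of fluoro gives a number 0.29 log units higher from compound 2 to compound 3 (within the scatter), and putting methyl in place of chloro gives a number 0.23 log units lower from compound 1 to compound 3 (within the scatter), so compound 3 cannot be told apart from either halogen compound. The two halogen compounds do remain distinct, with a number 0.52 log units lower from compound 1 to compound 2 (beyond the scatter), which means that methyl on this aromatic carbon, para to a large group, falls within the scatter of both ends of that one clear gap rather than extending the range they define. Nothing measured here explains why these three groups read as they do at this place.

The compounds shown span only fluoro, chloro and methyl, so it remains open whether an amine, a carboxylic acid or a longer chain on the same aromatic carbon would shift the read-out beyond the range these three occupy. On these data alone, it is also open whether the same exchanges would give the same steps at another carbon of this ring, since all three compounds carry their variable group at this single place.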